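The compounds below may be only part of what the source reports. "The series", "measured", "known", "first", "only" and "open" are said of these compounds alone.

Measured compounds:
Compound 1, `COc1ccc(/C=C/C(=O)c2ccccc2-c2cccc(F)c2)cc1OC`: 1200 nM
Compound 2, `COc1ccc(/C=C/C(=O)c2ccccc2-c2cccc(F)c2)cc1O`: 65 nM
Compound 3, `COc1ccc(C(=O)/C=C/c2ccccc2-c2ccc(F)cc2)cc1OC`: 7100 nM

All values come from a functional assay on MCF7 cells (Homo sapiens) for antiproliferative activity, read by sulforhodamine B assay, with a stated time of 48 h; a higher number here means a weaker inhibitor, a lower number a stronger inhibitor. Compound 2 differs from compound 1 only by hydrogen in place of methyl on an oxygen on an aromatic ring, and that single change gave an 18-fold lower number from compound 1 to compound 2 (1.27 log units; beyond the scatter). Compound 3 is built on a different core; it has the same atoms as compound 1 joined differently, and the difference between the two cores is not broken down here. In this assay compound 3 gives the highest number of the measured set.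

Compound 4, `COc1cc(C(=O)/C=C/c2ccccc2-c2ccc(F)cc2)ccc1O`, is not yet measured. It stands to compound 3 as compound 2 stands to compound 1: the change is hydrogen in place of methyl on an oxygen on an aromatic ring, and the place description matches the earlier one word for word, so it is the same change made on another core. Among the compounds with values here, the only guide is the step from compound 1 to compound 2; since the cores differ, a smaller step is expected, and the estimate for compound 4 rests on that one step, a 10-fold lower number from compound 3 to compound 4 (1.01 log units; beyond the scatter), giving an expected value of 700 nM with a range from 150 nM to 3000 nM.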

Compound 4, half-maximal inhibitory concentration: 5400 nM
Compound 4: middle estimate off by 7.7-fold (0.89 log units), on the low side; measured number outside the range, above it.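

In this assay, the change from methoxy to hydroxy gave a 1.3-fold lower number from compound 3 to compound 4 (0.12 log units; within the scatter), so the large gain seen on the core of compound 1 did not carry over to the second core. Set side by side, the two steps truly differ, which shows that what this change does depends on the core that carries it, at least for these two cores: the same change on two cores in this assay, an 18-fold lower number (1.27 log units; beyond the scatter) from compound 1 to compound 2 and a 1.3-fold lower number (0.12 log units; within the scatter) from compound 3 to compound 4, 14-fold (1.15 log units) apart, beyond the scatter of two such steps This does not show which part of the difference between the cores is responsible, since they hold the same atoms joined differently and that difference is not broken down here, and two pairs cannot give a rule for other cores.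

The compounds shown leave open whether an amine in place of the hydroxy, or an ethoxy or longer chain on that oxygen, would also behave differently on the two cores. They also leave open how the change from methoxy to hydroxy would fare on a third core.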